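The source may report more compounds than this note shows. Statements on the series, on what has been measured and on what is new or still open speak of the compounds shown alone.

Of the compounds shown here, three built on a shared core have been measured in a functional assay on A549 cells (Homo sapiens) for antiproliferative activity, read by MTT assay, with a stated time of 48 h; a lower number here means a stronger inhibitor, a higher number a weaker inhibitor. Compound 1 `Cc1ccccc1-n1nncc1CN1C(=O)C2(C(C#N)=C(N)Oc3c2c2nc4ccccc4nc2c2ccccc32)c2ccccc21` returns only a limit of the assay, > 50000 nM, which is the limit of > 50000 nM in this assay, at which 1 of the 3 values shown sits. Compound 2 `N#CC1=C(N)Oc2c(c3nc4ccccc4nc3c3ccccc23)C12C(=O)N(Cc1cnnn1-c1ccc(Br)cc1)c1ccccc12` gives 44300 nM. Compound 3 `CCc1ccccc1-n1nncc1CN1C(=O)C2(C(C#N)=C(N)Oc3c(N)cc4nc5ccccc5nc4c32)c2ccccc21`, which carries an additional amine on the core, gives 24600 nM; its gap to compound 2 lies within the scatter, so the two cannot be told apart, and compound 1 contributes no number to compare against. Going by the values given here, the single step measured between neighbours, an at least 1.1-fold lower number from compound 1 to compound 2 (0.05 log units; that floor lies within the scatter), exchanges the phenyl group on the aromatic nitrogen, and its floor lies inside the scatter.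

Compound 4 `N#CC1=C(N)Oc2c(N)cc3nc4ccccc4nc3c2C12C(=O)N(Cc1cnnn1-c1ccc([N+](=O)[O-])cc1)c1ccccc12` has not yet been measured. It differs from compound 3 in one place: 4-nitrophenyl in place of 2-ethylphenyl on an aromatic nitrogen. The step from compound 1 to compound 2 bears on this change, since it too swaps the phenyl group on the same aromatic nitrogen, and it produced only a small lowering whose floor sits within the scatter. No change beyond the scatter is therefore expected for compound 4 in this assay, with at most a mild lowering of the number. The step from compound 3 to compound 4 is estimated as a 1.2-fold lower number from compound 3 to compound 4 (0.09 log units; within the scatter). Compound 4 is expected to give about 20000 nM in this assay, between 8000 nM and 50000 nM.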

Compound 4, half-maximal inhibitory concentration: > 50000 nM
Compound 4: a limit, no number (the forecaster's own chance of this, stated with the estimate: 15%); middle value at least 2.5-fold (0.39 log units) away from the limit.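

Compound 4 returns only a limit of the assay, not a number, and that limit is shared: the limit of > 50000 nM in this assay, at which 2 of the 4 values shown sit.

In this assay, 4-nitrophenyl in place of 2-ethylphenyl gives an at least 2.0-fold higher number from compound 3 to compound 4 (0.30 log units; that floor lies within the scatter), so this exchange on the aromatic nitrogen brings no lowering of the number, an outcome the earlier compounds had not shown at this place. Set beside an at least 1.1-fold lower number from compound 1 to compound 2 (0.05 log units; that floor lies within the scatter), it shows that the two exchanges at this place do not run the same way, although both floors lie within the scatter and neither establishes a real change.

Going by these compounds alone, compound 3 remains the only compound with the additional amine on the core that gives a number, so it is open whether a plain phenyl, a 4-aminophenyl or a 4-methoxyphenyl on this nitrogen would keep a measurable value on that core. On these data alone, it is also open how 4-bromophenyl would behave on the core of compound 3, which would show whether the aryl groups act alike with and without the amine.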